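This account rests on a few compounds, and the source may have more. Where it says the series, first, only, none or still open, it means among the compounds named here.

For the measured compounds named here, the series is measured in a functional assay on SK-OV-3 cells (Homo sapiens) for inhibition, read by CCK-8 assay, with a stated time of 70 h (on this read-out lower numbers stand for stronger inhibition and higher numbers for weaker inhibition), and the three compounds with numbers so far share a chain of two ether-linked two-carbon units carrying an amine at one end and an aryl ether at the other. Compound 1 `c1ccc(COc2ccc(OCCOCCNc3ccncc3)cc2)cc1` gives 20600 nM. Compound 2 `O=[N+]([O-])c1cccc(COc2ccc(OCCOCCNC3CCCC3)cc2)c1` gives 15400 nM, the lowest number of the three, though compound 1 sits within the scatter of it, so the two cannot be ranked. Compound 3 `c1ccc2cc(OCCOCCNC3CCCC3)ccc2c1` gives 40600 nM, which does lie beyond the scatter above compound 2.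

Compound 4 `COC(=O)c1ccccc1COc1ccc(OCCOCCNC2CCCC2)cc1` has not yet been measured. It differs from compound 2 in a single place: 2-(methoxycarbonyl)phenyl in place of 3-nitrophenyl on a saturated chain carbon bound to an oxygen on an aromatic ring. Going by the values given here, no measured pair in this set shows what such a change does, so there is no step to lean on. Compound 4 is expected to land close to compound 2, with a step of a 1.1-fold higher number from compound 2 to compound 4 (0.04 log units; within the scatter) that is not expected to exceed the scatter in either direction. In this assay compound 4 is therefore estimated at 17000 nM, within a range from 6000 nM to 50000 nM.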

Compound 4, half-maximal inhibitory concentration: > 100000 nM
Compound 4: only a limit was reported; the forecaster's own chance of this, stated with the estimate: 10%; at least 5.8-fold (0.76 log units) between middle value and limit.
By their numbers in this assay, from the lowest: compounds 2, 1 and 3 (each within the scatter of the next, the first and the last beyond it). At a limit, above all of these: compound 4.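

For the compounds shown here, replacing 3-nitrophenyl with 2-(methoxycarbonyl)phenyl on a saturated chain carbon bound to an oxygen on an aromatic ring gives the first single-place comparison, with an at least 6.4-fold higher number from compound 2 to compound 4 (0.81 log units; beyond the scatter) in this assay. The reading for compound 4 is a limit of the assay, not a number: the limit of > 100000 nM in this assay, at which 1 of the 4 values shown sits. This place is therefore sensitive to the group it carries, even though both groups have one six-membered aromatic ring of carbon only, one double bond outside aromatic rings, the same hydrogen-bond counts and no net charge.

The compounds shown leave open whether this step follows the methoxycarbonyl group itself or the ring position given in the name 2-(methoxycarbonyl)phenyl. They also leave open how an unsubstituted phenyl, a carboxylic acid or an amide would read at this place.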